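This account rests on a few compounds, and the source may have more. Where it says the series, first, only, none or still open, it means among the compounds named here.

Compound 1 `C=C1CC[C@@H]2[C@](C)(CO[Si](C)(C)C(C)(C)C)[C@H](O)CC[C@@]2(C)[C@@H]1C/C=C1/C(=O)OC[C@H]1O`, compound 2 `C=C1CC[C@@H]2[C@](C)(CO[Si](c3ccccc3)(c3ccccc3)C(C)(C)C)[C@H](OC(C)=O)CC[C@@]2(C)[C@@H]1C/C=C1/C(=O)OC[C@H]1OC(C)=O` and compound 3 `C=C1CC[C@@H]2[C@](C)(CO[Si](C)(C)C(C)(C)C)[C@H](OC(C)=O)CC[C@@]2(C)[C@@H]1C/C=C1/C(=O)OC[C@H]1O` were all tested in a functional assay on P388 cells (Mus musculus) for cytotoxicity, read by sulforhodamine B assay; on this read-out higher numbers stand for an effect only at larger amounts of compound and lower numbers for an effect already at smaller amounts. In this assay compound 1 gives 8.39 uM, compound 2 gives 1.67 uM and compound 3 gives 1.71 uM. Compound 3 and compound 1 differ in just one place: hydrogen in place of acetyl on an oxygen on a saturated carbon This change produced a 4.9-fold higher number from compound 3 to compound 1 (0.69 log units; beyond the scatter). Compound 4 `C=C1CC[C@@H]2[C@](C)(CO[Si](c3ccccc3)(c3ccccc3)C(C)(C)C)[C@H](O)CC[C@@]2(C)[C@@H]1C/C=C1/C(=O)OC[C@H]1OC(C)=O` has not been measured yet. It stands to compound 2 exactly as compound 1 stands to compound 3, through the same change: hydrogen in place of acetyl on an oxygen on a saturated carbon The cores of compound 2 and compound 3 differ from each other in further ways, but that difference is not broken down here. Because the same change from compound 3 to compound 1 gave a 4.9-fold higher number from compound 3 to compound 1 (0.69 log units; beyond the scatter), the step from compound 2 to compound 4 is expected to be of a similar size, a 4.8-fold higher number from compound 2 to compound 4 (0.68 log units; beyond the scatter). Among the measured compounds shown here, only one earlier example of this change exists, so the expectation carries real uncertainty. Compound 4 is therefore estimated at 8 uM in this assay, with a likely range from 3.5 uM to 18 uM.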

Compound 4, concentration for half-maximal effect: 0.33 uM
Beside the measured number, compound 4's estimate is 24-fold (1.38 log units) above it; measured number below the stated range.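

In this assay the exchange of acetyl for hydrogen gives a 5.1-fold lower number from compound 2 to compound 4 (0.70 log units; beyond the scatter) and so, on this core, the compound with the free hydroxy shows its effect at smaller amounts. Set beside the earlier example, the same change does not carry over from one core to the other, not even in its direction: the same change on two cores in this assay, a 4.9-fold higher number (0.69 log units; beyond the scatter) from compound 3 to compound 1 and a 5.1-fold lower number (0.70 log units; beyond the scatter) from compound 2 to compound 4, 25-fold (1.39 log units) apart, beyond the scatter of two such steps. With only these two examples, this shows that in this series the outcome of the change depends on the core that carries it, but the cores differ in more than one place, so it does not show which of those differences matters or why the direction reverses.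

The compounds shown hold only acetyl or hydrogen on this oxygen, so it stays open how a methyl ether, a longer chain such as a butanoyl ester, or an amine in its place would behave on either core. Going by these compounds, it also stays open which direction the change would take on a third core.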